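A few compounds are considered here, and "the series" means these few. Any claim that something is new, unique, unknown or untested is made for them only; others in the source may bear on it.

Compound 1 `Fc1ccccc1CSc1nnc(-c2cnccn2)s1` carries a fluoro group on its benzyl ring and sits on a core built around a thiadiazole linked to a pyrazine. In a functional assay on SW 1116 cells (Homo sapiens) for antiproliferative activity, read by MTT assay, with a stated time of 48 h (on this read-out lower numbers stand for stronger inhibition and higher numbers for weaker inhibition), compound 1 gives 6770 nM. Compound 2 `Clc1ccccc1CSc1nnc(-c2cnccn2)s1` differs from it by chloro in place of fluoro on an aromatic carbon, and in this assay compound 2 gives 7530 nM. The resulting step is a 1.1-fold higher number from compound 1 to compound 2 (0.05 log units; within the scatter), so the two numbers cannot be told apart.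

Compound 3 `Fc1ccc(CSc2nnc(-c3cnccn3)n2-c2ccccc2)cc1` rests on a different core; the difference between the two cores is not broken down here. In this assay compound 3 gives 4120 nM, which lies within the scatter of both compound 1 and compound 2.

Compound 4 `Clc1ccc(CSc2nnc(-c3cnccn3)n2-c2ccccc2)cc1` has not yet been measured. It differs from compound 3 by chloro in place of fluoro on an aromatic carbon. This is the same kind of change as that from compound 1 to compound 2, though not the same: in the earlier pair the place is ortho to a large group, whereas here it is para to a large group. Within the data shown here, on the earlier pair, the swap moved the number only within the scatter, and there is no other example against which to weigh the change of position. For compound 4 in this assay the expected step is therefore a 1.1-fold higher number from compound 3 to compound 4 (0.04 log units; within the scatter). The estimate for compound 4 is 4500 nM, with a range expected between 2300 nM and 9000 nM, and the outcome will be known once compound 4 has been run.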

Compound 4, half-maximal inhibitory concentration: 12500 nM
For compound 4 the middle estimate is 2.8-fold (0.44 log units) below the measured one; the whole stated range lies below it.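

In this assay, chloro in place of fluoro gives a 3.0-fold higher number from compound 3 to compound 4 (0.48 log units; beyond the scatter), so on this core the swap from 4-fluorobenzyl to 4-chlorobenzyl weakens inhibition by a modest but readable amount. The same swap does not carry over with the same size from the core of compound 1 to the core of compound 3: the same change on two cores in this assay, a 1.1-fold higher number (0.05 log units; within the scatter) from compound 1 to compound 2 and a 3.0-fold higher number (0.48 log units; beyond the scatter) from compound 3 to compound 4, 2.7-fold (0.44 log units) apart, beyond the scatter of two such steps

This does not show why the two steps differ, since the two pairs differ in their core and also in where the halogen sits, para to a large group in the later pair and at another place in the earlier one, so the part played by the core cannot be separated from the part played by the place, and two pairs set no rule for the wider series.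

The compounds shown leave open whether the swap would read the same at one fixed place on both cores. They also leave open how a bromo, methyl or methoxy group, or a plain hydrogen, would stand against fluoro and chloro at the place para to a large group.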